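Thiophene for Phenyl on a Second Pyridine Core

This account rests on a few compounds, and the source may have more. Where it says the series, first, only, none or still open, it means among the compounds named here.

Four compounds share a core built around a six-membered aromatic ring with one nitrogen. Compound 1 `Oc1ccc(-c2cc(-c3ccc(Cl)cc3)nc(-c3ccsc3)c2)cc1`, compound 2 `Oc1ccc(-c2cc(-c3ccccc3)nc(-c3ccc(Cl)cc3)c2)cc1` and compound 3 `Oc1cccc(-c2cc(-c3ccccc3)nc(-c3ccccc3Cl)c2)c1` have been measured in a functional assay on HCT-15 cells (Homo sapiens) for cytotoxicity, read by CCK-8 assay and cell counting, with a stated time of 2 days; on this read-out higher numbers stand for weaker inhibition and lower numbers for stronger inhibition; compound 4 `Oc1cccc(-c2cc(-c3ccsc3)nc(-c3ccccc3Cl)c2)c1` has not. In this assay compound 1 gives 6240 nM, compound 2 gives 6920 nM and compound 3 gives 2930 nM. Compound 3 has the lowest number, with compound 1 nearest and compound 2 furthest. The change from compound 2 to compound 1 is thiophen-3-yl in place of phenyl on an aromatic carbon and gave a 1.1-fold lower number from compound 2 to compound 1 (0.04 log units; within the scatter). The same kind of change turns compound 3 into compound 4: thiophen-3-yl in place of phenyl on an aromatic carbon; here the place is meta to a 2-chlorophenyl group and a 3-hydroxyphenyl group rather than a 4-chlorophenyl group and a 4-hydroxyphenyl group, and the difference between the two cores is not broken down here. Because a 1.1-fold lower number from compound 2 to compound 1 (0.04 log units; within the scatter) lay within the scatter, the expected step is a 1.1-fold lower number from compound 3 to compound 4 (0.04 log units; within the scatter). Compound 4 is therefore estimated at 2700 nM, between 1300 nM and 5600 nM.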

Compound 4, half-maximal inhibitory concentration: 2500 nM
Compound 4: the middle estimate sits 1.1-fold (0.03 log units) above what was measured; the range from low to high includes it.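

In this assay, putting thiophen-3-yl in place of phenyl gives a 1.2-fold lower number from compound 3 to compound 4 (0.07 log units; within the scatter), and this step closely matches the one seen on the other core: the same change on two cores in this assay, a 1.1-fold lower number (0.04 log units; within the scatter) from compound 2 to compound 1 and a 1.2-fold lower number (0.07 log units; within the scatter) from compound 3 to compound 4, 1.1-fold (0.02 log units) apart, within the scatter of two such steps. On these two cores, then, the change carries over with the same result: the number stays within the scatter. Both steps are small, which shows that the change made no measurable difference here; it does not show any gain from thiophen-3-yl, and two pairs in one cell assay cannot predict the outcome on a further core.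

The compounds shown leave open whether an amine or a carboxylic acid could stand in place of the hydroxyl group. They also leave open how another five-membered ring, such as furan-3-yl, would compare.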